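The source may report more compounds than this note shows. Statements on the series, on what has been measured and on what is new or still open speak of the compounds shown alone.

Measured so far:
Compound 1 `CC(C)(C)OC(=O)C(O)Cn1cnc2c(N)ncnc21` — in a functional assay on HeLa cells (Homo sapiens) for cytotoxicity (on this read-out lower numbers stand for higher toxicity in this test and higher numbers for lower toxicity in this test), compound 1 gives > 400 ug/mL, which is a limit of the assay, not a number.
Compound 2 `CCCOC(=O)C(O)Cn1cnc2c(N)ncnc21` — in this assay compound 2 gives > 400 ug/mL, also a limit of the assay.

Compound 1 therefore stands at the upper edge of what the test can report, and so does every value shown here (the limit of > 400 ug/mL in this assay, at which 2 of the 2 values shown sit). Compound 3 `Nc1ncnc2c1ncn2CC(O)C(=O)OC1CCCCC1` is the next compound, differing from compound 1 by cyclohexyl in place of tert-butyl on an oxygen next to a carbonyl group. Among the compounds with values here, the only measured step that bears on a change at this oxygen, a step that the two limits leave unreadable from compound 1 to compound 2, cannot be sized: both of its ends are limits, so it shows neither a rise nor a fall in toxicity. Nothing here points to a step beyond the scatter. Compound 3 is thus expected to sit near the same edge, with an estimated step of a number no higher from compound 1 to compound 3 (the limit leaves the size open). The estimate for compound 3 is 400 ug/mL, in a range from 150 ug/mL to 1000 ug/mL.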

Compound 3, minimum cytotoxic concentration: 100 ug/mL
Estimate against measurement, compound 3: 4.0-fold (0.60 log units) above; measured number outside the range, below it.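

Cyclohexyl on the oxygen next to a carbonyl group brings a toxicity that this test can put a number on. In this assay it gives an at least 4.0-fold lower number from compound 1 to compound 3 (0.60 log units; beyond the scatter), and measured against propyl it gives an at least 4.0-fold lower number from compound 2 to compound 3 (0.60 log units; beyond the scatter). On these data alone, the step between compound 1 and compound 2 cannot be read, and the full size of both new steps stays open, because those two compounds stand at a limit: the limit of > 400 ug/mL in this assay, at which 2 of the 3 values shown sit.

The compounds shown do not separate the ring of cyclohexyl from its carbon count. A straight hexyl chain or a phenyl group on this oxygen would tell these apart.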